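The compounds below may be only part of what the source reports. "The series", "measured", "known", "first", "only" and "open" are said of these compounds alone.

Working notes on the series. Of the compounds shown here, two have been measured in a functional assay on the whole organism (strain Wistar) for inhibition, with Rattus norvegicus as the target, with stated times of 30 min and 2 h, at a dose of 20 mg/kg by the oral route; on this read-out lower numbers stand for less inhibition and higher numbers for more inhibition at the one dose given (going by the name of the read-out). Compound 1, `Cc1ccc(C(=O)CCc2nnc(-c3ccc(Cl)cc3)o2)c(C)c1`, gives 53.3% in this assay. Compound 2, `Cc1ccc(C(=O)CCc2nnc(Cc3ccccc3)o2)cc1`, gives 24.7% in this assay. Compound 2 stands at the lowest of the two numbers seen so far; the nearest is compound 1, a figure beyond the scatter above it. For the measured compounds named here, the two compounds differ in more than one place, so no single step between them can be read off, and the effect of any one change remains open.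

Compound 3, `Cc1ccc(C(=O)CCc2nnc(Cc3ccccc3)o2)c(C)c1`, is the next compound to be measured in this assay. Its relation to compound 2 is methyl in place of hydrogen on an aromatic carbon, the site being on an aromatic carbon of a six-membered aromatic ring of carbon only, ortho to a large group. Going by the values given here, no step between measured compounds is available to size this change. Compound 3 is expected to give a small upward step, a number 7.3 percentage points higher from compound 2 to compound 3 (within the scatter), not certainly beyond the scatter. The estimate for compound 3 in this assay is 32%, within 12% to 55%.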

Compound 3, a percentage reported as inhibition, in the whole organism at one dose (the size of the read-out at that dose, not a potency): 25.3%
For compound 3 the middle estimate is 6.7 percentage points above the measured one; the measured number falls inside the stated range.
By their numbers in this assay, from the lowest: compounds 2 and 3 (each within the scatter of the next); then compound 1.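

In this assay, the change from 4-methylphenyl to 2,4-dimethylphenyl gives a number 0.6 percentage points higher from compound 2 to compound 3 (within the scatter), so a methyl on this aromatic carbon, ortho to a large group, does not separate the two compounds at the one dose given. For the compounds shown here, with the 2,4-dimethylphenyl part held constant, benzyl in place of 4-chlorophenyl gives a number 28 percentage points lower from compound 1 to compound 3 (beyond the scatter), the first single change to lie beyond the scatter. Nothing available bears on why either step has this size.

On these data alone, it remains open whether a methoxy or an ethyl group on this aromatic carbon would also stay within the scatter, and whether the methyl would do so alongside 4-chlorophenyl. A plain phenyl group would be needed to separate the chlorine from the benzyl carbon link.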